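A Methyl Added to a Compound at the Assay Limit

This account rests on a few compounds, and the source may have more. Where it says the series, first, only, none or still open, it means among the compounds named here.

Of the compounds shown here, three have been measured in a functional assay on MCF7 cells (Homo sapiens) for inhibition; a higher number here means a weaker inhibitor, a lower number a stronger inhibitor. Compound 1 `Cc1cc(N)ccc1-c1nc2ccccc2s1` gives < 0.1 nM; < 0.1 nM (2 entries). Compound 2 `Cc1ccc2nc(-c3ccc(N)cc3Br)sc2c1` gives < 0.1 nM, which is a limit of the assay rather than a number. Compound 3 `Nc1ccc(-c2nc3ccccc3s2)c(I)c1` gives < 0.1 nM, also a limit.

Compound 3 therefore stands only at a limit, and the other two results are of the same kind, as the limit of < 0.1 nM in this assay, at which 2 of the 3 values shown sit, shows. Among the compounds with values here, no step between measured compounds can be sized. Compound 4 `Cc1ccc2nc(-c3ccc(N)cc3I)sc2c1` differs from compound 3 by methyl in place of hydrogen on an aromatic carbon. Compound 2 carries that methyl too and shows the limit. Compound 4 is expected to show no step beyond the scatter in this assay, with a step that the limit leaves unreadable from compound 3 to compound 4, and its estimate is 0.05 nM, between 0.01 nM and 0.2 nM.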

Compound 4, half-maximal inhibitory concentration: < 0.1 nM
Compound 4: a limit, no number; the forecaster's own chance of this, stated with the estimate: 85%; the middle value does not contradict the limit.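

Compound 4 gives only a limit, so no size can be read for its step from compound 3 or from compound 2: the limit of < 0.1 nM in this assay, at which 3 of the 4 values shown sit. The compounds shown leave open how strong each one truly is, and whether methyl or iodo changes that at all.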